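Aryl exchange in a series resting on its limit

This account rests on a few compounds, and the source may have more. Where it says the series, first, only, none or still open, it means among the compounds named here.

Compound 1 `Cc1ccc(Nc2ncc(C(F)(F)F)c(N3Cc4cccc(N(C)S(C)(=O)=O)c4C3)n2)c(Cl)c1`, compound 2 `CN(c1cccc2c1CN(c1nc(Nc3ccc(C(F)(F)F)cc3)ncc1C(F)(F)F)C2)S(C)(=O)=O` and compound 3 `Cc1cc(Cl)ccc1Nc1ncc(C(F)(F)F)c(N2Cc3cccc(N(C)S(C)(=O)=O)c3C2)n1` share one core and differ only in the aryl group on the amine nitrogen. In a functional assay on A549 cells (Homo sapiens) for antiproliferative activity, read by spectrophotometry, with a stated time of 2 days (on this read-out lower numbers stand for stronger inhibition of growth and higher numbers for weaker inhibition of growth), compound 2 gives > 30000 nM, which is a limit and not a number. Compound 1 gives > 30000 nM, which is also a limit. Within the data shown here, the series so far therefore reads as the limit of > 30000 nM in this assay, at which 2 of the 2 values shown sit.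

The change to compound 3 is 4-chloro-2-methylphenyl in place of 4-(trifluoromethyl)phenyl on a nitrogen on an aromatic ring, so 4-chloro-2-methylphenyl stands in place of 4-(trifluoromethyl)phenyl on a nitrogen on an aromatic ring. Among the measured compounds shown here, only one measured step bears on it, at the same place: a step that the two limits leave unreadable from compound 1 to compound 2. That step has no readable size, and it gives no direction for this change. Neither aryl group tested so far has produced a number in this assay, so no step beyond the scatter is expected. The expected step is a number no higher from compound 2 to compound 3 (the limit leaves the size open). For compound 3 the estimated value is 30000 nM, with an expected range of 12000 nM to 60000 nM, and a report as a limit is the likeliest outcome.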

Compound 3, concentration for 50% growth inhibition: 25500 nM
Compound 3: middle estimate off by 1.2-fold (0.07 log units), on the high side; low and high end bracket the measured number.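

In this assay, among these compounds, the aryl group on a nitrogen on an aromatic ring now gives a readable number for the first time, with compound 3 as the only member of the series off the limit. Placing 4-chloro-2-methylphenyl on that nitrogen gives an at least 1.1-fold lower number from compound 2 to compound 3 (0.07 log units; that floor lies within the scatter), while the exchange with 2-chloro-4-methylphenyl, which carries the same two substituents under a different name, gives an at least 1.1-fold lower number from compound 1 to compound 3 (0.07 log units; that floor lies within the scatter), so neither step is shown to exceed the usual scatter. The aryl position is therefore shown to admit a measurable value, but no real gain is established, and most of the series still rests on its limit: the limit of > 30000 nM in this assay, at which 2 of the 3 values shown sit.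

As far as these compounds go, the true sizes of both steps remain open, since each is only a floor, and the step between the other two compounds cannot be read because both of its ends are limits. Also open, from the compounds shown here alone, is whether a phenyl group carrying an amine or a carboxylic acid on the same nitrogen would give a step clearly beyond the scatter in this assay.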